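Swapping an iodine-bearing ring for a fluorine-bearing one

This account rests on a few compounds, and the source may have more. Where it says the series, first, only, none or still open, it means among the compounds named here.

Compound 1 `FC(F)(F)c1cccc(NC(=S)Nc2ccc(I)cc2)c1` was tested in an ADME assay on MDBK cells (Bos taurus) for cytotoxicity, read by MTT assay, with a stated time of 96 h (a higher number here means that more compound is tolerated, a lower number that less compound is tolerated), where compound 1 gives 9500 nM. Compound 2 `O=C(NC(=S)Nc1cccc(C(F)(F)F)c1)[C@H]1C[C@@H]2CC[C@H]1C2` gives 10000 nM in the same assay. Compound 1 thus has the smaller of the two numbers, but the two values sit within the usual scatter of each other. Compound 3 `Fc1ccccc1NC(=S)Nc1cccc(C(F)(F)F)c1` has not yet been measured. It differs from compound 1 in one place: 2-fluorophenyl in place of 4-iodophenyl on an amide-type nitrogen. Going by the values given here, no measured pair shows what this change does, so the expected step of a 1.1-fold higher number from compound 1 to compound 3 (0.02 log units; within the scatter) is taken to be none beyond the scatter. Compound 3 is therefore expected to give 10000 nM, within a range from 4000 nM to 25000 nM.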

Compound 3, half-maximal cytotoxic concentration: > 100000 nM
Compound 3: no number, only a limit (the forecaster's own chance of this, stated with the estimate: 15%); middle value at least 10-fold (1.00 log units) from the limit.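

On the amide-type nitrogen whose other neighbour is the thiocarbonyl carbon, the choice of aryl group can matter greatly in this assay: 2-fluorophenyl in place of 4-iodophenyl gives an at least 10-fold higher number from compound 1 to compound 3 (1.02 log units; beyond the scatter). Going by these compounds alone, no earlier step covered this place. For compound 3 the reading is a limit of the assay and not a number, so the full size of the step stays unknown: the limit of > 100000 nM in this assay, at which 1 of the 3 values shown sits.

This one change alters both the halogen and where it sits on the ring, and the compounds shown cannot separate the two. Going by these compounds, how a ring carrying an amine or a carboxylic acid would behave here also stays open.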